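A few compounds are considered here, and "the series" means these few. Any claim that something is new, unique, unknown or untested is made for them only; others in the source may bear on it.

Series notes, step from compound 3 to compound 4.

Three compounds share a core and differ only in the ring carried on an aromatic carbon. Compound 1 `CC(C)C[C@H](N)CN(C(=O)[C@@H]1C[C@H]1c1ccccc1)c1ccc(-c2ccncc2)cc1` gives 13000 nM in a functional assay for agonist activity at G protein-coupled receptor 88 (Homo sapiens), read by HTRF and cAMP accumulation; a higher number here means that more compound is needed for the effect, a lower number that less compound is needed. Compound 2 `CC(C)C[C@H](N)CN(C(=O)[C@@H]1C[C@H]1c1ccccc1)c1ccc(-c2cccs2)cc1` gives 1500 nM in this assay. Compound 3 `CC(C)C[C@H](N)CN(C(=O)[C@@H]1C[C@H]1c1ccccc1)c1ccc(-c2ccoc2)cc1` gives 2000 nM in this assay. Compound 3 therefore stands second highest of the three numbers: the step of a 1.3-fold higher number from compound 2 to compound 3 (0.12 log units; within the scatter) is within the scatter, while the step of a 6.5-fold lower number from compound 1 to compound 3 (0.81 log units; beyond the scatter) is beyond it, as is an 8.7-fold lower number from compound 1 to compound 2 (0.94 log units; beyond the scatter).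

Compound 4 `CC(C)C[C@H](N)CN(C(=O)[C@@H]1C[C@H]1c1ccccc1)c1ccc(C2=CCCCC2)cc1` carries the change (cyclohex-1-en-1-yl in place of furan-3-yl on an aromatic carbon). For the measured compounds named here, no measured step replaces an aromatic ring with a non-aromatic one, so none bears on it directly; the measured steps only show that swapping pyridin-4-yl for thiophen-2-yl or furan-3-yl lowers the number modestly, and that thiophen-2-yl and furan-3-yl sit within the scatter of each other. In this assay a step of a 1.3-fold higher number from compound 3 to compound 4 (0.10 log units; within the scatter) is expected, with no confident direction beyond the scatter. Compound 4 is estimated at 2500 nM, with a range of 700 nM to 9000 nM.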

Compound 4, half-maximal effective concentration: 1200 nM
Beside the measured number, compound 4's estimate is 2.1-fold (0.32 log units) above it; the range from low to high includes it.
By their numbers in this assay, from the lowest: compounds 4, 2 and 3 (each within the scatter of the next); then compound 1.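

In this assay, this place, on an aromatic carbon para to a large group, accepts a non-aromatic ring: cyclohex-1-en-1-yl reads level with the five-membered aromatic rings, with a 1.7-fold lower number from compound 3 to compound 4 (0.22 log units; within the scatter) and a 1.3-fold lower number from compound 2 to compound 4 (0.10 log units; within the scatter). Among these compounds, neither an aromatic ring nor a ring hetero atom is needed at this place to hold that level, and a six-membered ring of carbon only is accommodated as well. Compound 1 stays apart, with an 11-fold lower number from compound 1 to compound 4 (1.03 log units; beyond the scatter), and no measurement at hand accounts for that distance or for the level reading of the other three.

From the compounds shown here alone, whether the ring double bond matters remains open, and a saturated cyclohexyl or a plain phenyl would test it. Also open, going by these compounds, is how a basic amine ring such as piperidin-4-yl would read here.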